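Bromo for methyl on the pyridine oxygen series

This account rests on a few compounds, and the source may have more. Where it says the series, first, only, none or still open, it means among the compounds named here.

Measured so far in an assay on K177 cells with Neuronal acetylcholine receptor; alpha4/beta2 (Homo sapiens) as the target; on this read-out lower numbers stand for smaller maximal responses and higher numbers for larger maximal responses:
compound 1 `CN1CCC[C@H]1COc1cccnc1` gives 100%
compound 2 `CN1CCC[C@H]1COc1cccnc1Br` gives 12.3%
compound 3 `Cc1ccncc1OC[C@@H]1CCCN1C` gives 73.9%

Compound 3 stands second highest of the three numbers. Its nearest neighbour is compound 1, which lies above it by a number 26.1 percentage points lower from compound 1 to compound 3 (beyond the scatter); the furthest is compound 2, which lies far below it in this assay.

Compound 4 `CN1CCC[C@H]1COc1cnccc1Br` is not yet measured. The change from compound 3 is bromo in place of methyl on an aromatic carbon.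

Among the compounds with values here, two measured steps bear on it. The step from compound 1 to compound 2, bromo in place of hydrogen on an aromatic carbon, gave a number 87.7 percentage points lower from compound 1 to compound 2 (beyond the scatter). The step from compound 1 to compound 3, methyl in place of hydrogen on an aromatic carbon, gave a number 26.1 percentage points lower from compound 1 to compound 3 (beyond the scatter). Both substitutions of the ring lowered the response, and bromo did so far more than methyl. Within the data shown here, no measured pair shows bromo replacing methyl directly, so the expectation rests on the two steps above.

For compound 4 in this assay a drop beyond the scatter is expected, of about a number 48.9 percentage points lower from compound 3 to compound 4 (beyond the scatter), with the maximal response estimated at 25% and a range from 8% to 55%.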

Compound 4, largest response reached (reported as maximum), in percent of the reference or control that the assay uses: 14.1%
Compound 4: middle estimate off by 10.9 percentage points, on the high side; the range from low to high includes it.
By their numbers in this assay, from the lowest: compounds 2 and 4 (each within the scatter of the next); then compound 3; then compound 1.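

Within the data shown here, at the aromatic carbon opposite the ring nitrogen, methyl and bromo are not interchangeable in this assay: the direct exchange gives a number 59.8 percentage points lower from compound 3 to compound 4 (beyond the scatter) and separates two groups that the earlier compounds had compared only through their separate steps from compound 1. Against the unsubstituted compound, bromo at this carbon gives a number 85.9 percentage points lower from compound 1 to compound 4 (beyond the scatter), so among the compounds shown a low maximal response with bromo is not confined to the ring place it occupies in compound 2. In this assay, compound 2 at 12.3% and compound 4 at 14.1% lie within the scatter of each other, so this read-out does not separate these two bromo placements.

No data on hand account for the gap between methyl and bromo at this carbon. Still open, from the compounds shown here alone, is where a chloro, fluoro, methoxy or amino group at the same carbon would fall relative to compound 3 and compound 4, and whether a methyl group on the ring carbon that carries bromo in compound 2 would differ from that bromo group.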